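The compounds below may be only part of what the source reports. "The series", "measured", "known", "first", "only" and "open" are said of these compounds alone.

Going by the values given here, compound 1 `COc1ccc(/C=C/c2cc(OC)cc(OC)c2/C=C/C(=O)N2CCC(Cl)CC2)cc1` gives 2080 nM in a functional assay on A549 cells (Homo sapiens) for inhibition, read by MTT assay, with a stated time of 48 h (on this read-out lower numbers stand for stronger inhibition and higher numbers for weaker inhibition), the lowest of the two numbers measured so far. Its nearest neighbour is compound 2 `COc1ccc(/C=C/c2cc(OC)cc(OC)c2/C=C/C(=O)N(CC(C)C)CC(C)C)cc1`, which in this assay gives 3350 nM; the step of a 1.6-fold higher number from compound 1 to compound 2 (0.21 log units; within the scatter) lies within the scatter. Compound 3 `COc1ccc(/C=C/c2cc(OC)cc(OC)c2/C=C/C(=O)N2CCN(C)CC2)cc1` has not yet been measured. It differs from compound 1 in one place: 4-methylpiperazin-1-yl in place of 4-chloropiperidin-1-yl on a carbonyl carbon. Cut one bond further out, the change reads (4-chloropiperidin-1-yl)carbonyl to (4-methylpiperazin-1-yl)carbonyl. Among the compounds with values here, the only measured step that bears on this position is the one from compound 1 to compound 2, where a different group on the same carbonyl carbon moved the number by only a 1.6-fold higher number from compound 1 to compound 2 (0.21 log units; within the scatter). Within the data shown here, nothing among the measured compounds shows the 4-methylpiperazin-1-yl group itself. Compound 3 is therefore expected to sit close to compound 1, with a step of a 1.2-fold higher number from compound 1 to compound 3 (0.08 log units; within the scatter) that stays inside the scatter. The estimate for compound 3 in this assay is 2500 nM, with a range from 900 nM to 7000 nM.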

Compound 3, half-maximal inhibitory concentration: 4510 nM
Compound 3: middle estimate off by 1.8-fold (0.26 log units), on the low side, within the range that was stated.
By their numbers in this assay, from the lowest: compounds 1, 2 and 3 (each within the scatter of the next, the first and the last beyond it).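

In this assay, this position on the carbonyl carbon now shows its first step beyond the scatter: 4-methylpiperazin-1-yl in place of 4-chloropiperidin-1-yl gives a 2.2-fold higher number from compound 1 to compound 3 (0.34 log units; beyond the scatter), a modest step between two rings of equal heavy-atom count. The same group in place of diisobutylamino gives a 1.3-fold higher number from compound 2 to compound 3 (0.13 log units; within the scatter), so compound 2 and compound 3 cannot be told apart here. All three groups thus stay within a narrow span of numbers, and only the two ends of that span lie beyond the scatter of each other.

Going by these compounds, the swap from compound 1 to compound 3 alters the ring atom and its substituent together, so it remains open whether plain piperidin-1-yl or morpholin-4-yl would fall with compound 1 or with compound 3. On these data alone, whether an amide keeping the amide hydrogen, or a carboxylic acid on a longer chain, would be accepted at this carbonyl carbon also remains open. Nothing measured here accounts for the size of these steps.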